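The source may hold more compounds than are shown below. What is called first, only, known or untested is meant among the compounds shown, and "the series" means these compounds.

In a functional assay on NCI-H460 cells (Homo sapiens) for inhibition, read by CCK-8 assay, with a stated time of 72 h, tested at 10 uM (on this read-out lower numbers stand for less inhibition of growth and higher numbers for more inhibition of growth at the one concentration tested), compound 1 (`CN(C)C(=O)c1cc2cnc(Nc3ccc(NC(=O)C4(C(=O)Nc5cccc(O)c5)CC4)cc3)nc2n1C1CCCC1`) gives 94.9%. Within the data shown here, this is the higher of the two numbers available so far. Compound 2 (`Nc1ccc(NC(=O)C2(C(=O)Nc3ccc(F)cc3)CC2)cc1F`) gives 62.9%, a gap well beyond the usual scatter of such measurements. The two structures differ in more than one place, so this gap does not serve as a single structural step.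

Compound 3 (`CN(C)C(=O)c1cc2cnc(Nc3ccc(NC(=O)C4(C(=O)Nc5ccc(O)cc5)CC4)cc3)nc2n1C1CCCC1`) has not yet been measured in this assay. It keeps the core of compound 1 and differs from it in one place: 4-hydroxyphenyl in place of 3-hydroxyphenyl on an amide-type nitrogen. In words, it carries 4-hydroxyphenyl in place of 3-hydroxyphenyl on an amide-type nitrogen, with the same atoms joined differently. Among the measured compounds shown here, no measured pair shows what this swap does, so the expectation rests mainly on compound 1. Little room remains on this read-out because compound 1 reaches 94.9%, so a large rise is not possible. A large fall cannot be ruled out, but nothing measured points to one. The expected change is an estimated step of a number 4.9 percentage points lower from compound 1 to compound 3 (within the scatter), a slight fall that stays within the scatter. For compound 3 the estimated value is 90%, with an expected range of 72% to 100%.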

Compound 3, percent growth inhibition at one concentration: 104%
Estimate against measurement, compound 3: 14 percentage points below, and the stated range ends below it.
By their numbers in this assay, from the lowest: compound 2; then compounds 1 and 3 (each within the scatter of the next).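

Among these compounds, putting 4-hydroxyphenyl in place of 3-hydroxyphenyl on the amide-type nitrogen gives, in this assay, a number 9.1 percentage points higher from compound 1 to compound 3 (within the scatter), and this is the only single-place step available. With the core of compound 1 held fixed, the result shows that the two hydroxyphenyl groups at this position cannot be told apart on this read-out: the swap, which keeps the same atoms and joins them differently, leaves growth inhibition at the same level within the scatter, with compound 3 giving 104% at the upper end of the scale. No measurement shown here explains why the two groups read alike.

The compounds shown leave open whether this position accepts more than a change in where the hydroxyl sits on the ring, for example an unsubstituted phenyl, a 4-methoxyphenyl or a 4-aminophenyl on the same nitrogen with the rest of compound 1 unchanged. They also leave open whether compound 1 and compound 3 would separate at lower concentrations, as a single concentration near the top of the scale cannot show this.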